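The source may hold more compounds than are shown below. What is called first, only, known or untested is meant among the compounds shown, and "the series" means these compounds.

Measured so far:
compound 1 `Cc1cccc(NC(=O)CN2CCC(c3ccc(O)cc3)CC2)c1`: 70 nM
compound 2 `CSc1cccc(NC(=O)CN2CCC(c3cccc[n+]3[O-])CC2)c1`: 100 nM

Both compounds were tested in a functional assay on HEK293 cells for agonist activity at D(4) dopamine receptor (Homo sapiens), read by FLIPR; on this read-out higher numbers stand for an effect only at larger amounts of compound and lower numbers for an effect already at smaller amounts. Compound 1 gives 70 nM and compound 2 gives 100 nM; the two numbers sit close together, and their gap is within the usual scatter of repeated measurements, so neither can be called the stronger of the two. Among the measured compounds shown here, no pair of compounds that differ in only one place has yet been measured, so no single structural change has a known effect on this read-out.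

Compound 3 `COc1ccccc1C1CCN(CC(=O)Nc2cccc(C)c2)CC1` is the next compound, not yet measured. It differs from compound 1 in one place: 2-methoxyphenyl in place of 4-hydroxyphenyl on a saturated ring carbon

For the measured compounds named here, with no measured step to lean on, the expectation for compound 3 rests on the number of compound 1 alone. The step is expected to be small, a shift of a 1.4-fold lower number from compound 1 to compound 3 (0.15 log units; within the scatter) that stays within the scatter. Compound 3 is therefore estimated at 50 nM, in a range from 15 nM to 200 nM.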

Compound 3, half-maximal effective concentration: 420 nM
For compound 3 the middle estimate is 8.4-fold (0.92 log units) below the measured one, outside the stated range (above it).
By their numbers in this assay, from the lowest: compounds 1 and 2 (each within the scatter of the next); then compound 3.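

Among the compounds shown here, compound 3 gives the first measured single change: in this assay, 2-methoxyphenyl in place of 4-hydroxyphenyl on a saturated ring carbon gives a 6.0-fold higher number from compound 1 to compound 3 (0.78 log units; beyond the scatter) on the same shared core. This shows that the read-out responds to what this position carries, even though the entering and leaving groups are both six-membered aromatic carbon rings with an oxygen. Two things change together, since the oxygen group moves around the aromatic ring and the hydrogen-bond donor of 4-hydroxyphenyl is absent from 2-methoxyphenyl, and no supporting measurement accounts for the step.

The compounds shown leave open which of these two changes matters more. A 2-hydroxyphenyl or a 4-methoxyphenyl group at this position, each differing from compound 1 in one place, would help separate them.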